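From tetrahydroisoquinoline to hydroxypiperidine: a cytotoxicity estimate

The source may hold more compounds than are shown below. What is called first, only, known or untested is meant among the compounds shown, and "the series" means these compounds.

Compound 1 `Cc1ccc(S(=O)(=O)c2nc3ccccc3nc2N2CCCC2)cc1`: > 50000 nM, a limit of the assay
Compound 2 `O=S(=O)(c1ccccc1)c1nc2ccccc2nc1N1CCc2ccccc2C1`: 5010 nM
Compound 3 `Cc1ccc(S(=O)(=O)c2nc3ccccc3nc2N2CCc3ccccc3C2)cc1`: 22400 nM

In a functional assay on PC-3 cells (Homo sapiens) for cytotoxicity, read by MTT assay, with a stated time of 72 h (a lower number here means a stronger inhibitor, a higher number a weaker inhibitor), compound 3 gives 22400 nM, the higher of the two actual numbers, and compound 2 gives 5010 nM. Compound 4 `Cc1ccc(S(=O)(=O)c2nc3ccccc3nc2N2CCCC(O)C2)cc1` carries 3-hydroxypiperidin-1-yl in place of 1,2,3,4-tetrahydroisoquinolin-2-yl (3-hydroxypiperidin-1-yl in place of 1,2,3,4-tetrahydroisoquinolin-2-yl on an aromatic carbon). The closest measured change at this place is an at least 2.2-fold lower number from compound 1 to compound 3 (0.34 log units; beyond the scatter), an at least modest step; read backwards, it suggests that losing 1,2,3,4-tetrahydroisoquinolin-2-yl raises the number. The other step, a 4.5-fold higher number from compound 2 to compound 3 (0.65 log units; beyond the scatter), concerns a methyl that compound 4 keeps, so it does not bear on this change. A modest rise is therefore expected in this assay. The expected change is a 1.8-fold higher number from compound 3 to compound 4 (0.25 log units; within the scatter). Compound 4 is estimated at 40000 nM, with an expected range of 15000 nM to 100000 nM.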

Compound 4, half-maximal inhibitory concentration: 5330 nM
The estimate for compound 4 lay 7.5-fold (0.88 log units) above the measured number, and the stated range ends above it.
By their numbers in this assay, from the lowest: compounds 2 and 4 (each within the scatter of the next); then compound 3. At a limit, above all of these: compound 1.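

In this assay, the group at this position need not carry an aromatic ring to give a lower number: 3-hydroxypiperidin-1-yl in place of 1,2,3,4-tetrahydroisoquinolin-2-yl gives a 4.2-fold lower number from compound 3 to compound 4 (0.62 log units; beyond the scatter). With 3-hydroxypiperidin-1-yl in place of pyrrolidin-1-yl, the change is an at least 9.3-fold lower number from compound 1 to compound 4 (0.97 log units; beyond the scatter). Compound 1 gives > 50000 nM, which is a limit and not a number, so this step has no exact size.

The compounds shown leave open whether the hydroxyl or the six-membered ring matters more. A plain piperidin-1-yl on the same core would separate the two.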